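A few compounds are considered here, and "the series" means these few. Any claim that something is new, unique, unknown or untested is made for them only; others in the source may bear on it.

Values in a functional assay on MGC-803 cells (Homo sapiens) for inhibition, read by CCK-8 assay, with a stated time of 48 h; a higher number here means a weaker inhibitor, a lower number a stronger inhibitor:

- Compound 1 `CCN1CCN(CC(=O)N(Cc2ccc(OC)cc2)c2cc(OC)c(OC)c(OC)c2)CC1`: > 20000 nM (a limit of the assay, not a number)
- Compound 2 `COc1cc(N(Cc2ccc(Cl)cc2)C(=O)CSC(=S)N2CCN(C(=O)OC(C)(C)C)CC2)cc(OC)c1OC`: 12900 nM
- Compound 3 `COc1ccc(CN(C(=O)CSC(=S)N2CCN(C(=O)OC(C)(C)C)CC2)c2cc(OC)c(OC)c(OC)c2)cc1F`: 4870 nM

Compound 3 has the lower of the two actual numbers, and compound 2 stands higher by a margin beyond the usual scatter. Among the compounds with values here, that margin is the only measured step in the set: a 2.6-fold lower number from compound 2 to compound 3 (0.42 log units; beyond the scatter). It came from placing 3-fluoro-4-methoxyphenyl where 4-chlorophenyl had been.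

Compound 4 `COc1ccc(CN(C(=O)CSC(=S)N2CCN(C(=O)OC(C)(C)C)CC2)c2cc(OC)c(OC)c(OC)c2)cc1O` is not yet measured. It keeps everything in compound 3 except one group, with hydroxy in place of fluoro on an aromatic carbon, ortho to a methoxy group (hydroxy in place of fluoro on an aromatic carbon). The 3-fluoro-4-methoxybenzyl group thus becomes 3-hydroxy-4-methoxybenzyl.

Within the data shown here, no measured pair makes this exact swap. The nearest guide is the modest step into compound 3, which altered the same ring but changed more than this one group. It suggests that a change on this ring can matter, but it does not give a direction for the swap. A small change with no firm direction is therefore expected, and the step expected in this assay is a 1.1-fold lower number from compound 3 to compound 4 (0.03 log units; within the scatter). For compound 4 the estimated value is 4500 nM, with an expected range of 1600 nM to 13000 nM.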

Compound 4, half-maximal inhibitory concentration: 82 nM
The estimate for compound 4 lay 55-fold (1.74 log units) above the measured number, and the stated range ends above it.
By their numbers in this assay, from the lowest: compound 4; then compound 3; then compound 2. At a limit, above all of these: compound 1.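

In this assay, within the data shown here, the earlier compounds showed only a modest shift from changing this ring, and that change altered more than one group. Hydroxy in place of fluoro gives a 59-fold lower number from compound 3 to compound 4 (1.77 log units; beyond the scatter) and so shows that one heavy atom on an aromatic carbon, ortho to a methoxy group, can by itself move the number by a large margin, with the rest of the molecule unchanged. The wider comparison gives a 160-fold lower number from compound 2 to compound 4 (2.20 log units; beyond the scatter) for 3-hydroxy-4-methoxyphenyl in place of 4-chlorophenyl, far more than a 2.6-fold lower number from compound 2 to compound 3 (0.42 log units; beyond the scatter) seen with the fluoro compound, so within this set the large gain appears only once the hydroxy group is present, and nothing measured here explains why.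

The compounds shown leave open whether a hydroxy group is specifically required at this position, or whether an amino group or a carboxylic acid there would serve as well. They also leave open whether the gain survives when the tert-butoxycarbonyl group, shared by compound 2, compound 3 and compound 4, is replaced by a simple amine.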